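Benzylidene oxindole series: removal of one methoxy group

A few compounds are considered here, and "the series" means these few. Any claim that something is new, unique, unknown or untested is made for them only; others in the source may bear on it.

Working notes on the oxindole pair measured so far. Compound 1 `COc1ccc(/C=C2\C(=O)N(c3c(Cl)cccc3Cl)c3ccccc32)cc1OC` and compound 2 `O=C1/C(=C\c2cc3ccccc3nc2Cl)c2ccccc2N1c1c(Cl)cccc1Cl` share the same core and differ only in the group carried on the exocyclic double bond. In a functional assay on MIA PaCa-2 cells (Homo sapiens) for cytotoxicity, read by MTT assay, with a stated time of 72 h (a higher number here means that more compound is needed for the effect, a lower number that less compound is needed), compound 1 gives 5 ug/mL, and in this assay compound 2 gives 5 ug/mL. Compound 1 therefore stands level with compound 2 at the digits recorded; the two values sit within the scatter of the method, so no order between them can be stated.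

The next compound, compound 3 `COc1ccc(/C=C2\C(=O)N(c3c(Cl)cccc3Cl)c3ccccc32)cc1`, has not yet been measured in this assay. It differs from compound 1 by hydrogen in place of methoxy on an aromatic carbon, a hydrogen in place of methoxy on an aromatic carbon. Within the data shown here, no measured pair in this set describes such a change, so the size of the step has to be guessed. Given that the more substantial switch from compound 1 to compound 2 left the value unchanged within scatter, the step from compound 1 to compound 3 is expected to be small, with no confident direction, and at most a modest loss: a 1.2-fold higher number from compound 1 to compound 3 (0.08 log units; within the scatter). For compound 3 in this assay the estimate is 6 ug/mL, with a range from 2.5 ug/mL to 15 ug/mL.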

Compound 3, concentration for half-maximal effect: > 100 ug/mL
Compound 3 gave a limit, no number; the forecaster's own chance of this, stated with the estimate: 5%; at least 16-fold (1.22 log units) between middle value and limit.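

In this assay, the methoxy group on an aromatic carbon, ortho to a methoxy group and meta to a large group, proves far from silent: hydrogen in its place gives an at least 20-fold higher number from compound 1 to compound 3 (1.30 log units; beyond the scatter), a large step of which the level pair of compound 1 and compound 2 gave no hint. The reading for compound 3 is a limit of the assay and not a number: the limit of > 100 ug/mL in this assay, at which 1 of the 3 values shown sits. Among these compounds, compound 2, which carries no methoxy group, gives 5 ug/mL, so a methoxy group is not needed in every compound on the shared core, and the sensitivity to its loss is seen only in the single change from compound 1 to compound 3.

From the compounds shown here alone, whether the loss follows the oxygen or the whole group stays open: a hydroxy group, a fluorine atom or an amine on this carbon would separate the two, and nothing here tells whether the remaining methoxy group would behave alike. Among the compounds shown here, how far compound 3 lies past its limit also stays open, and the single step gives no cause for the loss.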